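Swapping a Methoxy for a Chloroacetamide

The source may report more compounds than this note shows. Statements on the series, on what has been measured and on what is new or still open speak of the compounds shown alone.

Measured compounds:
- compound 1, `COc1ccc(-c2nc3cc(C(F)(F)F)ccc3[nH]2)c(OC)c1`: > 100000 nM
- compound 2, `O=[N+]([O-])c1ccc(-c2nc3cc(C(F)(F)F)ccc3[nH]2)cc1`: 6000 nM
- compound 3, `COc1ccc(-c2nc3cc(C(F)(F)F)ccc3[nH]2)cc1`: 2000 nM

Of the compounds shown here, three sharing one core have been tested in an ADME assay on MT4 cells (Homo sapiens) for cytotoxicity, read by MTT assay, with a stated time of 96 h; a higher number here means that more compound is tolerated, a lower number that less compound is tolerated. Compound 1 gives only a limit of the assay, > 100000 nM, which means no number was reached (the limit of > 100000 nM in this assay, at which 1 of the 3 values shown sits). Compound 2 gives 6000 nM and compound 3 gives 2000 nM, the lowest of the two numbers; the step of a 3.0-fold lower number from compound 2 to compound 3 (0.48 log units; beyond the scatter) is modest, while the step of an at least 50-fold lower number from compound 1 to compound 3 (1.69 log units; beyond the scatter) is large.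

Compound 4, `O=C(CCl)Nc1ccc(-c2nc3cc(C(F)(F)F)ccc3[nH]2)cc1`, has not yet been measured. It differs from compound 3 by ((chloromethyl)carbonyl)amino in place of methoxy on an aromatic carbon. Going by the values given here, no measured step exchanges the methoxy for an amide-type group, so the bearing of the two known steps is indirect: the methoxy-to-nitro exchange moved the number only modestly, and no change at this position has yet made the number smaller than that of compound 3. Compound 4 is therefore expected to sit near compound 3, with the step of a 1.3-fold lower number from compound 3 to compound 4 (0.12 log units; within the scatter) estimated as small, and its value is estimated at 1500 nM, expected between 300 nM and 8000 nM.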

Compound 4, half-maximal cytotoxic concentration: 5000 nM
Estimate against measurement, compound 4: 3.3-fold (0.52 log units) below, and the stated range covers the measured number.
By their numbers in this assay, from the lowest: compound 3; then compounds 4 and 2 (each within the scatter of the next). At a limit, above all of these: compound 1.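

In this assay, the ((chloromethyl)carbonyl)amino group gives a 2.5-fold higher number from compound 3 to compound 4 (0.40 log units; beyond the scatter), so the methoxy of compound 3 still has the lowest number among the groups tried at this position. Exchanging the nitro for the same group gives a 1.2-fold lower number from compound 2 to compound 4 (0.08 log units; within the scatter), so compound 2 and compound 4 cannot be told apart, although they carry quite different groups. Two unlike groups at this position therefore end up at a similar level, and no measurement shown here explains why.

As far as these compounds go, the role of the chlorine remains open, and an acetamide without it, compared directly with compound 4, would address that. An amine or a carboxylic acid at this position would show whether other groups also stay in this range or move closer to compound 3.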